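This account rests on a few compounds, and the source may have more. Where it says the series, first, only, none or still open, it means among the compounds named here.

Compound 1 `CCn1cc(-c2nc3ccc([N+](=O)[O-])cc3[nH]2)c(=O)c2cc(F)c(N3CCNCC3)cc21` and compound 2 `CCn1cc(-c2nc3ccc([N+](=O)[O-])cc3[nH]2)c(=O)c2cc(F)c(N3CCN(C)CC3)cc21` share a core, and compound 2 differs from compound 1 by methyl in place of hydrogen on an amine nitrogen in a ring. In a functional assay on Bel-7402 cells (Homo sapiens) for cytotoxicity, read by MTT assay, with a stated time of 48 h (on this read-out higher numbers stand for weaker inhibition and lower numbers for stronger inhibition), compound 1 gives 2100 nM, while compound 2 gives 4400 nM, so the step of a 2.1-fold higher number from compound 1 to compound 2 (0.32 log units; beyond the scatter). Compound 3 `CCn1cc(-c2nc3ccc([N+](=O)[O-])cc3s2)c(=O)c2cc(F)c(N3CCNCC3)cc21` has a different core; the difference between the two cores is not broken down here. In this assay compound 3 gives 1800 nM. Compound 4 `CCn1cc(-c2nc3ccc([N+](=O)[O-])cc3s2)c(=O)c2cc(F)c(N3CCN(C)CC3)cc21` differs from compound 3 by methyl in place of hydrogen on an amine nitrogen in a ring, the same change that turns compound 1 into compound 2. Because the step of a 2.1-fold higher number from compound 1 to compound 2 (0.32 log units; beyond the scatter), a step of similar size is expected here, namely a 2.1-fold higher number from compound 3 to compound 4 (0.32 log units; beyond the scatter). On that basis compound 4 is estimated to give 3800 nM in this assay, most likely between 2000 nM and 7500 nM.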

Compound 4, half-maximal inhibitory concentration: 7700 nM
Beside the measured number, compound 4's estimate is 2.0-fold (0.31 log units) below it, and the stated range ends below it.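

Replacing piperazin-1-yl with 4-methylpiperazin-1-yl gives a 4.3-fold higher number from compound 3 to compound 4 (0.63 log units; beyond the scatter) in this assay, which means weaker inhibition, as it did on the other core. The two steps point the same way, and the gap between them is no larger than repeated measurements could produce, so the change carried over between these two cores: the same change on two cores in this assay, a 2.1-fold higher number (0.32 log units; beyond the scatter) from compound 1 to compound 2 and a 4.3-fold higher number (0.63 log units; beyond the scatter) from compound 3 to compound 4, 2.0-fold (0.31 log units) apart, within the scatter of two such steps. This does not show that the effect is larger on one core than on the other, and two pairs neither make a rule for further cores nor explain why the number rises.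

Still open, going by these compounds, is whether an ethyl group, a longer chain or an acetyl group on that ring nitrogen would shift the number in the same direction. On these data alone, it is also open whether the methyl step would hold on any third core.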